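Replacing the Hydroxynaphthyl Arm with a Dihydroxyphenyl

This account rests on a few compounds, and the source may have more. Where it says the series, first, only, none or still open, it means among the compounds named here.

Three compounds have been measured in a functional assay on MKN-45 cells (Homo sapiens) for cytotoxicity, read by MTT assay, with a stated time of 72 h; a lower number here means a stronger inhibitor, a higher number a weaker inhibitor:

Compound 1 `CN(C)CCn1cnnc1-c1cc(Oc2ccc(NC(=O)N/N=C/c3cc(C(C)(C)C)cc(C(C)(C)C)c3O)cc2F)ccn1`: 3300 nM
Compound 2 `CN(C)CCn1cnnc1-c1cc(Oc2ccc(NC(=O)N/N=C/c3c(O)ccc4ccccc34)cc2F)ccn1`: 2020 nM
Compound 3 `Cn1cnnc1-c1cc(Oc2ccc(NC(=O)N/N=C/c3ccccc3)cc2F)ccn1`: 7610 nM

Compound 2 gives the lowest number of the three. Compound 1 sits within the usual scatter of it, so the two cannot be ranked against each other; compound 3 lies beyond the scatter and is the weaker inhibitor of that pair.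

Compound 4 `CN(C)CCn1cnnc1-c1cc(Oc2ccc(NC(=O)N/N=C/c3ccc(O)cc3O)cc2F)ccn1` has not yet been tested in this assay. It differs from compound 2 in one place: 2,4-dihydroxyphenyl in place of 2-hydroxynaphthalen-1-yl on a carbon with a double bond to nitrogen. Going by the values given here, no step of this kind has been measured here, so the expectation rests on compound 2 alone, whose value of 2020 nM is the starting point. Among the compounds with values here, a modest step toward a higher number is expected, a 1.7-fold higher number from compound 2 to compound 4 (0.24 log units; within the scatter), since the only compound with a single ring at this position, compound 3, gave 7610 nM. Compound 4 is therefore estimated at 3500 nM, with a range from 1500 nM to 9000 nM.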

Compound 4, half-maximal inhibitory concentration: 2860 nM
Estimate against measurement, compound 4: 1.2-fold (0.09 log units) above, within the range that was stated.
By their numbers in this assay, from the lowest: compounds 2, 4 and 1 (each within the scatter of the next); then compound 3.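

In this assay, the step is a 1.4-fold higher number from compound 2 to compound 4 (0.15 log units; within the scatter), so the two compounds cannot be told apart. At this position, then, a single aromatic ring with 2,4-dihydroxyphenyl substitution serves as well as the two-ring 2-hydroxynaphthalen-1-yl arm, and the second ring is not needed to hold this level of cell-killing activity. Nothing available here explains this result.

Still open, as far as these compounds go, is which of the two hydroxyl groups on the new ring matters, if either does. A methoxy group or an amine in their place would test this.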